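Removing the furan from compound 2: what to expect

A few compounds are considered here, and "the series" means these few. Any claim that something is new, unique, unknown or untested is made for them only; others in the source may bear on it.

Of the compounds shown here, two sharing one core have been measured in an ADME assay on HepG2 cells (Homo sapiens) for cytotoxicity, read by MTT assay, with a stated time of 72 h; on this read-out higher numbers stand for lower toxicity in this test and lower numbers for higher toxicity in this test. Compound 1 `CC1(c2ccc(-c3ccccc3C#N)cc2)CC(S(=O)(=O)c2ccc(F)cc2)=C(c2ccc(/C(N)=N\O)cc2)O1` gives 58300 nM. Going by the values given here, compound 2 `CC1(c2ccc(-c3ccco3)cc2)CC(S(=O)(=O)c2ccc(F)cc2)=C(c2ccc(/C(N)=N\O)cc2)O1` gives 7010 nM, the lower of the two numbers, and the only change between them was an 8.3-fold lower number from compound 1 to compound 2 (0.92 log units; beyond the scatter). Compound 3 `CC1(c2ccccc2)CC(S(=O)(=O)c2ccc(F)cc2)=C(c2ccc(/C(N)=N\O)cc2)O1` differs from compound 2 by hydrogen in place of furan-2-yl on an aromatic carbon, so that the position para to a large group now carries only hydrogen. Among the compounds with values here, the single step measured so far touched this same position, and exchanging one aromatic group for another there shifted the number clearly. Taking the group away altogether has no direct precedent among these compounds, so the direction is open. The expectation for compound 3 is therefore a number lying between the two measured values, amounting to a step of a 2.9-fold higher number from compound 2 to compound 3 (0.46 log units; beyond the scatter). The estimate for compound 3 is 20000 nM, with a range from 5000 nM to 80000 nM.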

Compound 3, half-maximal cytotoxic concentration: 68300 nM
The estimate for compound 3 lay 3.4-fold (0.53 log units) below the measured number; the range from low to high includes it.
By their numbers in this assay, from the lowest: compound 2; then compounds 1 and 3 (each within the scatter of the next).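

In this assay, taking the furan-2-yl group away gives a clear change (a 9.7-fold higher number from compound 2 to compound 3 (0.99 log units; beyond the scatter)), so on this position that group goes with the lower number, which stands for higher toxicity in this test. The 2-cyanophenyl group behaves differently: replacing it with hydrogen leaves the number within the scatter (a 1.2-fold higher number from compound 1 to compound 3 (0.07 log units; within the scatter)). An aromatic group at this position therefore does not lower the number simply by being there, and the gap seen earlier between compound 1 and compound 2 now traces to the furan-2-yl group alone.

From the compounds shown here alone, whether a small amine, a carboxylic acid or a thiophene ring on this carbon would go with a low number, as furan-2-yl does, or match hydrogen, stays open. Nothing available explains why these two groups part ways here.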